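Dichlorophenyl in place of fluorophenyl on the shared core

This account rests on a few compounds, and the source may have more. Where it says the series, first, only, none or still open, it means among the compounds named here.

Measured compounds:
- Compound 2, `Cc1n[nH]c2ccc(-c3nc4cnc(N5CCN(C)CC5)cn4c3Nc3ccc(F)cc3)cc12`: 32300 nM
- Compound 3, `Cc1n[nH]c2ccc(-c3nc4cnc(N5CCN(C)CC5)cn4c3Nc3ccc(Br)cc3)cc12`: 2600 nM
- Compound 1, `Cc1n[nH]c2ccc(-c3nc4cnc(N5CCN(C)CC5)cn4c3Nc3cccc(F)c3)cc12`: "not determined" (no result reported)

Among the compounds with values here, in a functional assay on MV4-11 cells (Homo sapiens) for inhibition, with a stated time of 120 h (a higher number here means a weaker inhibitor, a lower number a stronger inhibitor), compound 2 gives 32300 nM, the highest of the two numbers known; its nearest neighbour is compound 3, and a 12-fold lower number from compound 2 to compound 3 (1.09 log units; beyond the scatter) is a large step. Compound 4, `Cc1n[nH]c2ccc(-c3nc4cnc(N5CCN(C)CC5)cn4c3Nc3ccc(Cl)cc3Cl)cc12`, carries the change (2,4-dichlorophenyl in place of 4-fluorophenyl on a nitrogen on an aromatic ring). Within the data shown here, the only step that bears on it is the one from compound 2 to compound 3, where a heavier halogen in the same position gave a much lower number. Chlorine sits between fluorine and bromine, and a second chlorine enters as well, so a lower number than that of compound 2 is expected, with a 5.4-fold lower number from compound 2 to compound 4 (0.73 log units; beyond the scatter) as the estimated size. Compound 4 is therefore expected to give 6000 nM, within 1500 nM to 25000 nM.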

Compound 4, half-maximal inhibitory concentration: 4720 nM
Compound 4: middle estimate off by 1.3-fold (0.10 log units), on the high side; low and high end bracket the measured number.
By their numbers in this assay, from the lowest: compounds 3 and 4 (each within the scatter of the next); then compound 2.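

In this assay there is a 6.8-fold lower number from compound 2 to compound 4 (0.84 log units; beyond the scatter) and so the drop seen with 4-bromophenyl is not unique to that group, since 2,4-dichlorophenyl on the same nitrogen also lowers the number. Replacing 4-bromophenyl gives a 1.8-fold higher number from compound 3 to compound 4 (0.26 log units; within the scatter) and so this position does not separate these two groups. No measurement at hand explains either step.

Steps involving compound 1 cannot be read. Still open, going by these compounds, is how much each chlorine contributes, and whether a methoxy group or an amine on the phenyl ring would give a similarly low number.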